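The source may report more compounds than this note shows. Statements on the series, on what has been measured and on what is new or still open speak of the compounds shown alone.

Compound 3 `CC(=O)Nc1ccc(-n2nncc2CN2C(=O)C3(C(C#N)=C(N)Oc4c(N)cc5nc6ccccc6nc5c43)c3ccccc32)cc1` stands at the edge of what a functional assay on HCT-116 cells (Homo sapiens) for antiproliferative activity, read by MTT assay, with a stated time of 48 h (a higher number here means a weaker inhibitor, a lower number a stronger inhibitor), can report: its value of > 50000 nM is a limit of the assay, not a measured number. Compound 1 `Cc1cc(C)cc(-n2nncc2CN2C(=O)C3(C(C#N)=C(N)Oc4c3c3nc5ccccc5nc3c3ccccc43)c3ccccc32)c1` likewise gives only a limit, > 50000 nM. Going by the values given here, compound 2 `N#CC1=C(N)Oc2c(N)cc3nc4ccccc4nc3c2C12C(=O)N(Cc1cnnn1-c1cccc(C(F)(F)F)c1)c1ccccc12` is the one compound here with a real number, 18900 nM. Among the compounds with values here, the step of an at least 2.6-fold higher number from compound 2 to compound 3 (0.42 log units; beyond the scatter) shows that swapping one aryl group for the other on the aromatic nitrogen pushed the value out to the limit, and two of the three values so far sit at the limit of > 50000 nM in this assay, at which 2 of the 3 values shown sit.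

Compound 4 `Cc1cc(C)cc(-n2nncc2CN2C(=O)C3(C(C#N)=C(N)Oc4c(N)cc5nc6ccccc6nc5c43)c3ccccc32)c1` differs from compound 3 in this way: 3,5-dimethylphenyl in place of 4-acetamidophenyl on an aromatic nitrogen. Within the data shown here, the 3,5-dimethylphenyl group already appears in compound 1, which gives only a limit, but compound 1 lacks the amino group on the core, and no single step connects it to compound 4. The only measured step at this position moved the number upward and out of range, and nothing among these compounds shows a move back down. For compound 4 the step of a number no higher from compound 3 to compound 4 (the limit leaves the size open) is therefore expected to be small or none, with the value most likely remaining at the limit. The estimate for compound 4 in this assay is 50000 nM, within 15000 nM to 200000 nM.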

Compound 4, half-maximal inhibitory concentration: > 50000 nM
Compound 4: a limit, no number; the forecaster's own chance of this, stated with the estimate: 65%; the middle value sits exactly at the limit.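

In this assay, the change to 3,5-dimethylphenyl gives an at least 2.6-fold higher number from compound 2 to compound 4 (0.42 log units; beyond the scatter), so a second replacement of 3-(trifluoromethyl)phenyl on the aromatic nitrogen also moves the result out to the limit. The 3,5-dimethylphenyl group has no hydrogen-bond donor or acceptor, whereas 4-acetamidophenyl has both, so the move to the limit does not require those features of the acetamide; the step between compound 3 and compound 4 itself cannot be read, as both give only a limit and not a number. Among the compounds that carry the amino group on the core, compound 2 alone now gives a real number, and the limit dominates the set: the limit of > 50000 nM in this assay, at which 3 of the 4 values shown sit.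

On these data alone, it remains open whether 3-(trifluoromethyl)phenyl is unusual in giving a number here, or whether a plain phenyl, a 4-chlorophenyl or a benzyl group on the same nitrogen would also stay within the range of the assay. As far as these compounds go, how far compound 3 and compound 4 lie beyond the limit also remains unknown, so no order can be given between them.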